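The compounds below may be only part of what the source reports. "The series", "measured", "known", "first", "only" and "open" are said of these compounds alone.

Working notes on the series. Three measured compounds and one not yet measured share a core: compound 1 `Nc1ccc(S(=O)(=O)c2ccc(NC(=O)NCc3ccccc3)cc2)cc1`, compound 2 `CC(NS(=O)(=O)c1ccc(N)cc1)c1ccccc1`, compound 3 `Nc1ccc(S(=O)(=O)NCc2ccc(Cl)cc2)cc1` and compound 4 `COc1ccc(CNS(=O)(=O)c2ccc(N)cc2)cc1`. In an assay on isolated protein for inhibition of protein arginine N-methyltransferase 1 (Homo sapiens), read by ELISA, tested at 50 uM (on this read-out higher numbers stand for a stronger effect at the one concentration tested and lower numbers for a weaker effect), compound 1 gives 13.6% and compound 2 gives 40%. For compound 3 only a limit of the assay is known, < 5%, the value sitting at the limit of < 5% in this assay, at which 1 of the 3 values shown sits. Compound 3 thus stands at the lowest point of the numbers shown; no step between the measured compounds is given. Compound 4 differs from compound 3 by methoxy in place of chloro on an aromatic carbon. For the measured compounds named here, with no measured step of this kind to lean on, the expected movement is small, a number at least 5 percentage points higher from compound 3 to compound 4 (that floor lies within the scatter), not clearly beyond the scatter. Compound 4 is estimated at 10%, between 0% and 30%.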

Compound 4, a percentage reported as inhibition, at one concentration (the size of the read-out at that concentration, not a potency): 19%
Compound 4: the middle estimate sits 9 percentage points below what was measured; low and high end bracket the measured number.
By their numbers in this assay, from the lowest: compounds 1 and 4 (each within the scatter of the next); then compound 2. At a limit, below all of these: compound 3.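

For the compounds shown here, the earlier compounds gave no step in one place, so this is the first reading of a single change. In this assay, methoxy in place of chloro on an aromatic carbon, para to a large group, gives a number at least 14 percentage points higher from compound 3 to compound 4 (beyond the scatter), so the group at this position does move the read-out. That size is only a floor, as the value of compound 3 is a limit of the assay: the limit of < 5% in this assay, at which 1 of the 4 values shown sits.

As far as these compounds go, it remains open whether the read-out follows the methoxy itself or the loss of chloro. From the compounds shown here alone, how a hydroxy group, an amine or a longer chain such as ethoxy would read at this position also remains open.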